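Exchanging methoxy for oxan-2-yl on the shared core

This account rests on a few compounds, and the source may have more. Where it says the series, first, only, none or still open, it means among the compounds named here.

Of the compounds shown here, two have numbers so far. In a physicochemical assay for solubility (a lower number here means a less soluble compound, a higher number a more soluble compound), compound 1 (`COc1ccc2c(c1)CN(C(=O)c1cc(S(C)(=O)=O)ccc1O[C@@H](C)C(F)(F)F)C2`) gives (46 ug/mL) and compound 2 (`Cc1cccc2c1CN(C(=O)c1cc(S(C)(=O)=O)ccc1O[C@@H](C)C(F)(F)F)C2`) gives (73 ug/mL). Among the compounds with values here, these two values lie within the scatter of each other, so compound 1 stands level with the only other measured compound.

Compound 3 (`C[C@H](Oc1ccc(S(C)(=O)=O)cc1C(=O)N1Cc2ccc(C3CCCCO3)cc2C1)C(F)(F)F`) keeps the core of compound 1 and carries oxan-2-yl in place of methoxy on an aromatic carbon. The entering group brings one six-membered non-aromatic ring with 1 hetero atom, and the site is meta to a fused ring and para to a fused ring.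

Within the data shown here, no measured pair shows this exchange or any other single change, so the expectation in this assay rests on the structural change and on compound 1 (46 ug/mL) as the starting value. The estimated step is small and towards a lower number (a 1.5-fold lower number from compound 1 to compound 3 (0.19 log units; within the scatter)), and it is not expected to pass beyond the scatter. For compound 3 the expected value is 30 ug/mL (estimated range 10 ug/mL to 80 ug/mL).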

Compound 3, solubility: < 1 ug/mL
Compound 3 gave a limit, no number; the forecaster's own chance of this, stated with the estimate: 5%; middle value at least 30-fold (1.47 log units) from the limit.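

In this assay, within the data shown here, the exchange of methoxy for oxan-2-yl on this aromatic carbon, meta to a fused ring and para to a fused ring, gives the first single change that can be read, and the step is large: an at least 46-fold lower number from compound 1 to compound 3 (1.66 log units; beyond the scatter). From the compounds shown here alone, the reading for compound 3, < 1 ug/mL, is a limit and not a number, so the step fixes only a minimum size and the full size stays unknown. The site is therefore not indifferent to what it carries, at least for this one exchange, and the result lies at the end of the measurable range: the limit of < 1 ug/mL in this assay, at which 1 of the 3 values shown sits.

Going by these compounds, a single pair cannot separate the ring of oxan-2-yl from its larger count of heavy atoms, so it remains open which of the two goes with the step. Also open, on these data alone, is how an amine, a carboxylic acid or an open-chain ether such as ethoxy on the same aromatic carbon of the shared core would read in this assay.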